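Chain-to-ring swap in the amino acid series

The compounds below may be only part of what the source reports. "The series", "measured", "known", "first", "only" and "open" are said of these compounds alone.

Compound 2 `CCCCCc1c(C(N)C(=O)O)cnn1O` is the reference point here. In a functional assay on CHO cells for agonist activity at metabotropic glutamate receptor 1 (Rattus norvegicus), read by calcium flux (on this read-out lower numbers stand for an effect already at smaller amounts and higher numbers for an effect only at larger amounts of compound), compound 2 gives > 1000000 nM, which is a limit of the assay and not a number. Compound 1 `CCc1c(C(N)C(=O)O)cnn1O` carries the shorter chain on the same core. In this assay compound 1 gives > 1000000 nM, again a limit. For the measured compounds named here, the only measured step, a step that the two limits leave unreadable from compound 1 to compound 2, therefore has no readable size, since both values sit at the limit of > 1000000 nM in this assay, at which 2 of the 2 values shown sit.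

Compound 3 `NC(C(=O)O)c1cnn(O)c1CC1CC1` differs from compound 2 in one place: cyclopropyl in place of butyl on a saturated chain carbon bound to an aromatic carbon. Going by the values given here, no measured step bears directly on this change. Among the compounds with values here, the single step, from the shorter to the longer chain, is unreadable between two limits, so it gives neither a direction nor a size to carry over. Within the data shown here, nothing measured so far moves the read-out off the limit. No step beyond the scatter is expected in this assay in either direction. The expected step of a number no higher from compound 2 to compound 3 (the limit leaves the size open) is flat. Compound 3 is estimated at 1000000 nM, with a range from 200000 nM to 5000000 nM, and most probably the assay will again return only a limit.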

Compound 3, half-maximal effective concentration: > 1000000 nM
Compound 3: a limit, no number; the forecaster's own chance of this, stated with the estimate: 85%; the middle value lies on the limit itself.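

In this assay compound 3 gives > 1000000 nM, a limit and not a number. No new step can be read among compound 1, compound 2 and compound 3, as all three values rest at the same limit: the limit of > 1000000 nM in this assay, at which 3 of the 3 values shown sit.

The compounds shown leave open whether any chain on the shared core gives a measurable effect, and how such chains would rank.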